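A few compounds are considered here, and "the series" means these few. Any claim that something is new, unique, unknown or untested is made for them only; others in the source may bear on it.

The measured compounds are compound 1 `CNC(=O)c1cc(Oc2ccc(NC(=O)c3cc4cccnc4n(-c4ccc(OC)cc4)c3=O)cc2)ccn1` with 920 nM, compound 2 `CNC(=O)c1cc(Oc2ccc(NC(=O)c3cc4cccnc4n(-c4ccc(Br)cc4F)c3=O)cc2)ccn1` with 1950 nM, and compound 3 `CCCNC(=O)c1cc(Oc2ccc(NC(=O)c3cc4cccnc4n(-c4ccc(OC)cc4)c3=O)cc2)ccn1` with 1560 nM, all read in a functional assay on HT-29 cells (Homo sapiens) for antiproliferative activity, read by MTT assay, with a stated time of 72 h; a higher number here means a weaker inhibitor, a lower number a stronger inhibitor.

Compound 1 and compound 2 share one core and differ only by 4-bromo-2-fluorophenyl in place of 4-methoxyphenyl on an aromatic nitrogen. That change gave a 2.1-fold higher number from compound 1 to compound 2 (0.33 log units; beyond the scatter). Compound 3 carries a different core: how it differs from compound 1 is given by ethyl in place of hydrogen on a saturated chain carbon bound to an amide-type nitrogen, and this change gave a 1.7-fold higher number from compound 1 to compound 3 (0.23 log units; within the scatter). Compound 4 `CCCNC(=O)c1cc(Oc2ccc(NC(=O)c3cc4cccnc4n(-c4ccc(Br)cc4F)c3=O)cc2)ccn1` has not yet been measured in this assay. It differs from compound 3 by 4-bromo-2-fluorophenyl in place of 4-methoxyphenyl on an aromatic nitrogen, which is the same change as that between compound 1 and compound 2; the place where it happens is described in identical terms for both pairs, so the two occurrences are the same change made on two cores.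

Going by the values given here, only one measured example of this change exists, so the expectation rests on that single step. Among the compounds with values here, compound 4 is expected to show a 2.1-fold higher number from compound 3 to compound 4 (0.31 log units; beyond the scatter), of a size close to the measured step, because a 2.1-fold higher number from compound 1 to compound 2 (0.33 log units; beyond the scatter) is the only measured instance of the change. Compound 4 is therefore estimated to give 3200 nM in this assay, with a range from 1600 nM to 6500 nM expected to cover most repeat measurements.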

Compound 4, half-maximal inhibitory concentration: 2160 nM
Beside the measured number, compound 4's estimate is 1.5-fold (0.17 log units) above it; low and high end bracket the measured number.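

In this assay, 4-bromo-2-fluorophenyl in place of 4-methoxyphenyl on an aromatic nitrogen gave a 1.4-fold higher number from compound 3 to compound 4 (0.14 log units; within the scatter), and this step does not differ measurably from the earlier one on the core of compound 1: the same change on two cores in this assay, a 2.1-fold higher number (0.33 log units; beyond the scatter) from compound 1 to compound 2 and a 1.4-fold higher number (0.14 log units; within the scatter) from compound 3 to compound 4, 1.5-fold (0.18 log units) apart, within the scatter of two such steps. Ethyl in place of hydrogen on a saturated chain carbon bound to an amide-type nitrogen gave a 1.1-fold higher number from compound 2 to compound 4 (0.04 log units; within the scatter), and this change also carried from one core to the other without a measurable difference: the same change on two cores in this assay, a 1.7-fold higher number (0.23 log units; within the scatter) from compound 1 to compound 3 and a 1.1-fold higher number (0.04 log units; within the scatter) from compound 2 to compound 4, 1.5-fold (0.18 log units) apart, within the scatter of two such steps. This shows only that each change behaved compatibly on the two cores shown; it does not show that either change has a fixed size across the series, and the aryl change cannot be said to raise the number on every core, since only its step on the core of compound 1 lies beyond the scatter.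

The compounds shown leave open whether the same steps would hold with an unsubstituted phenyl or a pyridyl ring on the aromatic nitrogen. They also leave open what a longer chain, or a chain ending in an amine or a carboxylic acid, would do on the amide nitrogen in this assay.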